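The source may report more compounds than this note shows. Statements on the series, on what has been measured and on what is new or still open speak of the compounds shown alone.

Measured compounds:
Compound 1 `CS(=O)(=O)CCCn1c(Cn2cc(S(C)(=O)=O)c3cc(F)ccc32)nc2cc(Cl)ccc21` gives > 100000 nM in an ADME assay on HEp-2 cells (Homo sapiens) for cytotoxicity, with a stated time of 4 days (on this read-out higher numbers stand for lower toxicity in this test and lower numbers for higher toxicity in this test), which is a limit of the test and not a number.
Compound 2 `CS(=O)(=O)CCCn1c(Cn2nc(S(C)(=O)=O)c3ccccc32)nc2cc(Cl)ccc21` gives > 100000 nM in this assay, again a limit rather than a number.
Compound 3 `CS(=O)(=O)CCCn1c(Cn2nc(S(C)(=O)=O)c3ccncc32)nc2cc(Cl)ccc21` gives > 100000 nM in this assay, also a limit rather than a number.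

Compound 3 therefore stands where every measured compound stands: at the limit of > 100000 nM in this assay, at which 3 of the 3 values shown sit. For the measured compounds named here, none of the three compounds has a numerical read-out, so no step between measured compounds can be sized, and nothing in these values separates one compound from another.

Compound 4 `CS(=O)(=O)c1nn(Cc2nc3cc(Cl)ccc3n2CCO)c2cnccc12` is the untested compound. Its change from compound 3 is hydroxy in place of (methylsulfonyl)methyl on a saturated chain carbon, two bonds along the chain from an aromatic nitrogen, that is, 3-(methylsulfonyl)propyl becomes 2-hydroxyethyl on the chain that hangs from the shared core.

With every measured value sitting at the same limit, there is no measured basis for expecting a shift in either direction in this assay; the expectation for compound 4 is no step beyond the scatter, as a number no higher from compound 3 to compound 4 (the limit leaves the size open) states. Compound 4 is estimated at 100000 nM, with a range from 30000 nM to 300000 nM, and a strong chance that the test again reports only a limit.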

Compound 4, half-maximal cytotoxic concentration: > 100000 nM
Compound 4: a limit, no number (the forecaster's own chance of this, stated with the estimate: 75%); the middle value sits exactly at the limit.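

No step from compound 3 to compound 4 can be read, since both results are limits of the test and not numbers: the limit of > 100000 nM in this assay, at which 4 of the 4 values shown sit.

The compounds shown leave open whether 3-(methylsulfonyl)propyl or 2-hydroxyethyl on the chain makes any difference to the toxicity seen in this assay.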